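The source may hold more compounds than are shown below. What is called first, only, known or untested is meant among the compounds shown, and "the series" means these compounds.

Measured so far:
Compound 1, `CO[C@H]1C[C@H](O[Si](C)(C)C(C)(C)C)O[C@@H](C)/C1=C/CCl`, in a functional assay on the whole organism for inhibition, with Artemia salina as the target; a higher number here means a weaker inhibitor of growth, a lower number a stronger inhibitor of growth: 0.01 ug/mL
Compound 2, `CO[C@H]1C[C@H](O[Si](C)(C)C(C)(C)C)O[C@@H](C)/C1=C/C=O`, in this assay: 0.01 ug/mL
Compound 3, `CO[C@H]1C[C@H](O[Si](C)(C)C(C)(C)C)O[C@@H](C)/C1=C/C(=O)O`, in this assay: 0.002 ug/mL

Compound 3 stands lowest of the three in this assay, its nearest neighbour being compound 1 with the step a number 2.3 two-fold dilutions lower from compound 1 to compound 3 (beyond the scatter), and compound 2 lying the same distance away with a number 2.3 two-fold dilutions lower from compound 2 to compound 3 (beyond the scatter). Between compound 1 and compound 2 the step is no change at the digits printed from compound 1 to compound 2 (within the scatter), so the chloromethyl and formyl ends read alike and only the carboxy end sets compound 3 apart.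

Compound 4, `CO[C@H]1C[C@H](O[Si](C)(C)C(C)(C)C)O[C@@H](C)/C1=C/C(=O)N1CCCCC1`, differs from compound 3 by piperidin-1-yl in place of hydroxy on a carbonyl carbon. The step that bears on it most directly is the one on the same carbonyl carbon, a number 2.3 two-fold dilutions lower from compound 2 to compound 3 (beyond the scatter), where adding the hydroxy gave the modest gain. Compound 4 again carries no hydroxy there, so that gain is not expected to hold; at the same time nothing measured shows a carbonyl bearing a ring substituent, and the common tendency of this series to stay within a narrow band argues against a large move in either direction. The expectation for compound 4 is therefore a step a number 1.6 two-fold dilutions higher from compound 3 to compound 4 (beyond the scatter) in this assay, back toward the level of compound 1 and compound 2, giving an estimated value of 0.006 ug/mL with a range from 0.002 ug/mL to 0.02 ug/mL.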

Compound 4, minimum inhibitory concentration: 0.002 ug/mL
Estimate against measurement, compound 4: 1.6 two-fold dilutions above, and the stated range covers the measured number.
By their numbers in this assay, from the lowest: compounds 3 and 4 (each within the scatter of the next); then compounds 1 and 2 (each within the scatter of the next).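

In this assay, piperidin-1-yl in place of hydroxy on a carbonyl carbon gives no change at the digits printed from compound 3 to compound 4 (within the scatter), so the low reading of this pair does not depend on a free carboxy group or on the hydrogen-bond donor counted for its hydroxy. The low level now holds for two different ends on this carbonyl carbon, and the (piperidin-1-yl)carbonyl end stands apart from the formyl end, with a number 2.3 two-fold dilutions lower from compound 2 to compound 4 (beyond the scatter), and from the chloromethyl end, with a number 2.3 two-fold dilutions lower from compound 1 to compound 4 (beyond the scatter). Nothing available gives a reason for this shared level or tells why a group as large as piperidin-1-yl is accepted in place of hydroxy.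

The compounds shown leave open whether the level depends on the piperidine ring at all or would hold for a methyl ester, a primary amide or an open-chain diethylamide on the same carbonyl carbon. They also leave open whether a morpholine amide reads alike, and whether any of these ends keeps its reading with a free hydroxy in place of the tert-butyldimethylsilyloxy group on the shared core.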